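Swapping the group on the sulfonyl sulfur of compound 3

This account rests on a few compounds, and the source may have more. Where it says the series, first, only, none or still open, it means among the compounds named here.

Compound 1 `CNC(=O)c1[nH]c(C)c2c1CCCCC2=O` carries the shared core, but in a functional assay on SK-MEL-5 cells (Homo sapiens) for inhibition, with a stated time of 72 h (a higher number here means a weaker inhibitor of growth, a lower number a stronger inhibitor of growth), compound 1 has only the entry "not determined" (no result reported), so it offers no number for comparison. Two larger relatives do have numbers. In this assay compound 2 `CCN(CC)S(=O)(=O)c1ccc(OC)c(NC(=O)c2[nH]c(C)c3c2CCCCC3=O)c1` gives 16300 nM, and in the same test compound 3 `COc1ccc(S(=O)(=O)N2CC3(COC3)C2)cc1NC(=O)c1[nH]c(C)c2c1CCCCC2=O` gives 20800 nM. Within the data shown here, these two values lie within the scatter of each other, so compound 3 stands level with the only other compound that has a number.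

Compound 4 `COc1ccc(S(=O)(=O)N2CCCCCC2)cc1NC(=O)c1[nH]c(C)c2c1CCCCC2=O` has not yet been measured. It differs from compound 3 in one place: a group of 7 heavy atoms (6 carbon, 1 nitrogen; one seven-membered non-aromatic ring with 1 hetero atom) in place of a group of 7 heavy atoms (5 carbon, 1 nitrogen, 1 oxygen; 2 four-membered non-aromatic rings with 1 hetero atom each), on a sulfonyl sulfur. The entering group is azepan-1-yl, and the group that leaves has no common name.

Among the measured compounds shown here, the one measured step that bears on this change sits on the same kind of sulfonyl sulfur: a 1.3-fold higher number from compound 2 to compound 3 (0.11 log units; within the scatter). A different group there left the number within the scatter, although a single step is thin evidence. No change beyond the scatter is therefore expected in this assay. The expected step is a 1.3-fold lower number from compound 3 to compound 4 (0.11 log units; within the scatter), which stays within the scatter. Compound 4 is estimated at 16000 nM, with an expected range from 8000 nM to 32000 nM.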

Compound 4, concentration for 50% growth inhibition: 6850 nM
Compound 4: the middle estimate sits 2.3-fold (0.37 log units) above what was measured; the measured number lies below the stated range.
By their numbers in this assay, from the lowest: compound 4; then compounds 2 and 3 (each within the scatter of the next).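

The group on the sulfonyl sulfur can move the number beyond the scatter in this assay, which the earlier step (a swap of diethylamino for the group with two four-membered rings) did not show: there the result was a 1.3-fold higher number from compound 2 to compound 3 (0.11 log units; within the scatter) and stayed within the scatter. Azepan-1-yl gives a real gain over both earlier groups, with (a 3.0-fold lower number from compound 3 to compound 4 (0.48 log units; beyond the scatter)) and (a 2.4-fold lower number from compound 2 to compound 4 (0.38 log units; beyond the scatter)), so compound 4 is the strongest inhibitor of growth among the three compounds with numbers, though both steps are modest and the number remains high. Nothing measured here says why azepan-1-yl does better than either group it replaces.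

The step from compound 3 to compound 4 swaps the ring system and also removes the oxygen, so the compounds shown cannot separate those two changes, and compound 3 shows that carrying rings does not by itself lower the number. Piperidin-1-yl, with a smaller ring and no oxygen, and morpholin-4-yl, with a single ring that keeps an oxygen, would help to tell whether ring size or the oxygen matters more on this sulfonyl sulfur.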